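Iodo Substitution and Microsomal Stability in an Acrylamide Series

The source may hold more compounds than are shown below. What is called first, only, known or untested is meant among the compounds shown, and "the series" means these compounds.

Measured in an ADME assay on microsomes from liver (Rattus norvegicus) for metabolic stability, read by LC-MS, using NADPH, with a stated time of 30 min, tested at 1 uM; on this read-out lower numbers stand for a less stable compound and higher numbers for a more stable compound:
Compound 1 `C=CC(=O)Nc1cc(Nc2ncc(I)c(Nc3ccccc3S(=O)(=O)N(C)C)n2)c(OC)cc1N(C)CCN(C)C`: 12%
Compound 2 `C=CC(=O)Nc1cc(Nc2nccc(Nc3ccccc3S(=O)(=O)N(C)C)n2)c(OC)cc1N(C)CCN(C)C`: 6%
Compound 3 `C=CC(=O)Nc1cc(Nc2nccc(Nc3ccccc3S(=O)(=O)C(C)C)n2)c(OC)cc1N(C)CCN(C)C`: 22%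

Compound 2 is the common point of comparison. One change from it gives compound 1, described as iodo in place of hydrogen on an aromatic carbon, and the numbers move by a number 6 percentage points higher from compound 2 to compound 1 (within the scatter). The other change gives compound 3, described as isopropyl in place of dimethylamino on a sulfonyl sulfur, and here the numbers move by a number 16 percentage points higher from compound 2 to compound 3 (beyond the scatter). Compound 3 and compound 1 lie within the scatter of each other in this assay.

Compound 4 `C=CC(=O)Nc1cc(Nc2ncc(I)c(Nc3ccccc3S(=O)(=O)C(C)C)n2)c(OC)cc1N(C)CCN(C)C` is not yet measured. It differs from compound 3 by iodo in place of hydrogen on an aromatic carbon, the same change as that from compound 2 to compound 1, at the same place. Since that earlier step was a number 6 percentage points higher from compound 2 to compound 1 (within the scatter), a step of similar size is expected from compound 3 to compound 4, namely a number 6 percentage points higher from compound 3 to compound 4 (within the scatter). Compound 4 is therefore estimated at 28% in this assay, expected to fall between 15% and 42%.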

Compound 4, percent of the compound remaining: 14%
Compound 4: middle estimate off by 14 percentage points, on the high side; the measured number lies below the stated range.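

In this assay, iodo in place of hydrogen on the core of compound 3 gave a number 8 percentage points lower from compound 3 to compound 4 (within the scatter), and set beside the earlier step on the other core this gives no sign of a real difference: the same change on two cores in this assay, a number 6 percentage points higher (within the scatter) from compound 2 to compound 1 and a number 8 percentage points lower (within the scatter) from compound 3 to compound 4, 14 percentage points apart, within the scatter of two such steps. The change of isopropyl in place of dimethylamino, made on the iodo core, gave a number 2 percentage points higher from compound 1 to compound 4 (within the scatter), and this pair of steps also stays unseparated: the same change on two cores in this assay, a number 16 percentage points higher (beyond the scatter) from compound 2 to compound 3 and a number 2 percentage points higher (within the scatter) from compound 1 to compound 4, 14 percentage points apart, within the scatter of two such steps. The two cores therefore show no measurable dependence of either change on its core, but this does not show that the steps carry over unchanged, since each change is seen only once on each of two cores and the iodo steps on both lie within the scatter.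

The compounds shown leave open how chloro or fluoro on the same aromatic carbon would read in this assay. They also leave open whether a cyclic amine such as morpholine, or a longer alkyl chain, on the sulfonyl sulfur would follow the isopropyl steps.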